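This account rests on a few compounds, and the source may have more. Where it says the series, first, only, none or still open, it means among the compounds named here.

In a physicochemical assay for solubility, read by HPLC, in phosphate buffer, measured as kinetic solubility, at pH 7.4 (on this read-out lower numbers stand for lower solubility and higher numbers for higher solubility), compound 3 `CCC(=O)c1cc(-c2cccc(Cl)c2)n(-c2ccc(S(N)(=O)=O)cc2)c1C` gives 12600 nM. Compound 1 `CCC(=O)c1cc(-c2ccc(OC)cc2)n(-c2ccc(S(N)(=O)=O)cc2)c1C` gives 12800 nM, within the scatter of that number, while compound 2 `CCC(=O)c1cc(-c2ccc(C)cc2)n(-c2ccc(S(N)(=O)=O)cc2)c1C` gives 1000 nM. The unmeasured compound 4 `CCC(=O)c1cc(-c2ccccc2Cl)n(-c2ccc(S(N)(=O)=O)cc2)c1C` has the same atoms as compound 3, joined differently: 2-chlorophenyl in place of 3-chlorophenyl on an aromatic carbon. It carries 2-chlorophenyl in place of 3-chlorophenyl, next to the ring nitrogen. Among the compounds with values here, no measured step makes this exact change. The closest are a 1.0-fold lower number from compound 1 to compound 3 (0.01 log units; within the scatter), which lies within the scatter, and the large 13-fold higher number from compound 2 to compound 3 (1.10 log units; beyond the scatter), which is matched in size by a 13-fold lower number from compound 1 to compound 2 (1.11 log units; beyond the scatter). Within the data shown here, with no direct precedent, the expectation is a step within the scatter, held loosely: a 1.0-fold higher number from compound 3 to compound 4 (0.01 log units; within the scatter) is the estimated step. Compound 4 is expected at 13000 nM, within an estimated range of 4000 nM to 40000 nM.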

Compound 4, solubility: 38200 nM
The estimate for compound 4 lay 2.9-fold (0.47 log units) below the measured number, and the stated range covers the measured number.
By their numbers in this assay, from the lowest: compound 2; then compounds 3 and 1 (each within the scatter of the next); then compound 4.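

In this assay, the position next to the ring nitrogen responds to where the chlorine sits on the phenyl group, although the atoms stay the same: 2-chlorophenyl in place of 3-chlorophenyl gives a modest step (a 3.0-fold higher number from compound 3 to compound 4 (0.48 log units; beyond the scatter)). Compound 4 also stands clear of the 4-methoxyphenyl compound (a 3.0-fold higher number from compound 1 to compound 4 (0.47 log units; beyond the scatter)) and further still from the 4-methylphenyl compound (a 38-fold higher number from compound 2 to compound 4 (1.58 log units; beyond the scatter)), so it has the highest number of the four, beyond the scatter. Nothing available accounts for these steps. The compounds shown leave open whether 2-methylphenyl, 2-methoxyphenyl or 2-fluorophenyl would follow 2-chlorophenyl at this position, and how a phenyl group carrying an amine would read.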